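Enone amide extension across two cores: antiproliferative notes

This account rests on a few compounds, and the source may have more. Where it says the series, first, only, none or still open, it means among the compounds named here.

Measured so far in a functional assay on MCF7 cells (Homo sapiens) for antiproliferative activity, read by MTT assay, with a stated time of 72 h; a higher number here means a weaker inhibitor, a lower number a stronger inhibitor:
Compound 1 `CC(C)=CC(=O)Nc1cccc(Oc2nc(Nc3cccc(C#N)c3)nc3c2CSCC3)c1` gives > 50000 nM, a limit of the assay and not a number.
Compound 2 `CC(C)/C=C/C(=O)Nc1cccc(Oc2nc(Nc3cccc(C#N)c3)nc3c2CSCC3)c1` gives 29600 nM.
Compound 3 `COc1ccc(Nc2nc3c(c(Oc4cccc(NC(=O)C=C(C)C)c4)n2)CSCC3)cn1` gives 22200 nM.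

The entry for compound 1 is a limit only (the limit of > 50000 nM in this assay, at which 1 of the 3 values shown sits). Compound 2 differs from compound 1 by 3-methylbut-1-en-1-yl in place of 2-methylprop-1-en-1-yl on a carbonyl carbon, and the step is an at least 1.6-fold lower number from compound 1 to compound 2 (0.22 log units; that floor lies within the scatter). Compound 3 differs from compound 1 in the core, (6-methoxypyridin-3-yl in place of 3-cyanophenyl on a nitrogen on an aromatic ring), with a step of an at least 2.2-fold lower number from compound 1 to compound 3 (0.35 log units; beyond the scatter). Compound 3 and compound 2 lie within the scatter of each other.

Compound 4 `COc1ccc(Nc2nc3c(c(Oc4cccc(NC(=O)/C=C/C(C)C)c4)n2)CSCC3)cn1` is not yet measured. It differs from compound 3 by 3-methylbut-1-en-1-yl in place of 2-methylprop-1-en-1-yl on a carbonyl carbon, the same change already seen, at the same place, a carbonyl carbon whose other neighbours are an amide-type nitrogen. Because the earlier step of an at least 1.6-fold lower number from compound 1 to compound 2 (0.22 log units; that floor lies within the scatter) rests on a limit, only a floor is known; for compound 4 a step of a 1.6-fold lower number from compound 3 to compound 4 (0.20 log units; within the scatter) in this assay is expected. Compound 4 is estimated at 14000 nM, between 6000 nM and 35000 nM.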

Compound 4, half-maximal inhibitory concentration: 37100 nM
For compound 4 the middle estimate is 2.7-fold (0.42 log units) below the measured one; measured number outside the range, above it.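

In this assay, 3-methylbut-1-en-1-yl in place of 2-methylprop-1-en-1-yl gives a 1.7-fold higher number from compound 3 to compound 4 (0.22 log units; within the scatter), and this change does not carry over as one fixed step: the same change on two cores in this assay, an at least 1.6-fold lower number (0.22 log units; that floor lies within the scatter) from compound 1 to compound 2 and a 1.7-fold higher number (0.22 log units; within the scatter) from compound 3 to compound 4, at least 2.8-fold (0.45 log units) apart, beyond the scatter of two such steps. The swap to 6-methoxypyridin-3-yl gives a 1.3-fold higher number from compound 2 to compound 4 (0.10 log units; within the scatter), and it likewise differs between the two settings: the same change on two cores in this assay, an at least 2.2-fold lower number (0.35 log units; beyond the scatter) from compound 1 to compound 3 and a 1.3-fold higher number (0.10 log units; within the scatter) from compound 2 to compound 4, at least 2.8-fold (0.45 log units) apart, beyond the scatter of two such steps. Compound 1 gives > 50000 nM, a limit and not a number, so both gaps are floors on which the comparison depends, and the data show no cause for them.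

Still open, going by these compounds, is whether the mismatch extends to other chains on the carbonyl carbon, such as a longer chain or one ending in an amine. Also open, on these data alone, is how a carboxylic acid on the ring carried by the nitrogen would behave.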